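A few compounds are considered here, and "the series" means these few. Any claim that something is new, unique, unknown or untested is made for them only; others in the source may bear on it.

Measured compounds in the series:

Compound 1, `COc1cc(Nc2ncc(C(F)(F)F)c(N3Cc4cccc(N(C)S(C)(=O)=O)c4C3)n2)c(OC)cc1Cl`, gives 16500 nM in a functional assay on HeLa cells (Homo sapiens) for antiproliferative activity, read by spectrophotometry, with a stated time of 2 days; on this read-out higher numbers stand for weaker inhibition of growth and lower numbers for stronger inhibition of growth.
Compound 2, `CN(c1cccc2c1CN(c1nc(Nc3ccc(Nc4ccccc4)cc3)ncc1C(F)(F)F)C2)S(C)(=O)=O`, gives 7300 nM in this assay.

Compound 1 has the highest number of the two in this assay; the nearest is compound 2, whose number is lower by a gap beyond the usual scatter, so compound 1 is the weaker grower-inhibitor of the two measured here.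

The step of interest goes from compound 1 to compound 3, `COc1cc(Nc2ncc(C(F)(F)F)c(N3Cc4cccc(N(C)S(C)(=O)=O)c4C3)n2)cc(C(F)(F)F)c1`, which has not yet been measured in this assay. The change is 3-methoxy-5-(trifluoromethyl)phenyl in place of 4-chloro-2,5-dimethoxyphenyl on a nitrogen on an aromatic ring. The group that leaves carries one chlorine and two oxygens; the group that enters carries three fluorines and one oxygen, both on the same nitrogen of the shared core.

Going by the values given here, no step between measured compounds bears on this change, so there is nothing to scale it against. The expectation is for a change of modest size in this assay, with no direction that can be called beyond the scatter from what is shown. Compound 3 is estimated at 12000 nM, within 3000 nM to 45000 nM, which corresponds to an expected step of a 1.4-fold lower number from compound 1 to compound 3 (0.14 log units; within the scatter).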

Compound 3, concentration for 50% growth inhibition: 5100 nM
Beside the measured number, compound 3's estimate is 2.4-fold (0.37 log units) above it; the measured number falls inside the stated range.
By their numbers in this assay, from the lowest: compounds 3 and 2 (each within the scatter of the next); then compound 1.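

In this assay the group on a nitrogen on an aromatic ring now has a readable effect: 3-methoxy-5-(trifluoromethyl)phenyl in place of 4-chloro-2,5-dimethoxyphenyl gives a 3.2-fold lower number from compound 1 to compound 3 (0.51 log units; beyond the scatter) and this lies beyond the scatter. The shared core therefore keeps its growth inhibition in this assay when the chlorine leaves and a trifluoromethyl enters, and compound 3 at 5100 nM and compound 2 at 7300 nM lie within the scatter of each other despite their different groups on this nitrogen. No measurement given here accounts for the step, so it stays unassigned to any part of the exchange.

The chlorine, the methoxy groups and the trifluoromethyl all change together, so a phenyl carrying only a methoxy or only a trifluoromethyl would be needed to separate their contributions. Also open, from the compounds shown here alone, is whether an amine or a carboxylic acid on this phenyl would move the number further in this assay and whether the step holds on other cell lines.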